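Bromine on the fused ring of a naphthyl ketone series

The source may hold more compounds than are shown below. What is called first, only, known or untested is meant among the compounds shown, and "the series" means these compounds.

Of the compounds shown here, three that share one core have been measured in an ADME assay on C8166 cells (Homo sapiens) for cytotoxicity, read by colorimetric assay and MTT assay; on this read-out lower numbers stand for higher toxicity in this test and higher numbers for lower toxicity in this test. Compound 1 `Cc1ccc(C)c(C(=O)c2c(OCC(=O)Nc3ccc(S(N)(=O)=O)cc3C)ccc3ccccc23)c1` gives 47500 nM in this assay. Compound 2 `Cc1ccc(C(=O)c2c(OCC(=O)Nc3ccc(S(N)(=O)=O)cc3C)ccc3ccccc23)cc1C` gives 33000 nM. Compound 3 `Cc1cc(S(N)(=O)=O)ccc1NC(=O)COc1ccc2ccccc2c1C(=O)c1cc(Cl)cc(Br)c1` gives 36600 nM. Compound 2 holds the smallest of the three numbers, yet the gap a 1.4-fold lower number from compound 1 to compound 2 (0.16 log units; within the scatter) and the gap a 1.1-fold higher number from compound 2 to compound 3 (0.04 log units; within the scatter) both sit within the scatter, so the three compounds cannot be told apart on these data; the third pairing, a 1.3-fold lower number from compound 1 to compound 3 (0.11 log units; within the scatter), is likewise within the scatter.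

Compound 4 `Cc1ccc(C(=O)c2c(OCC(=O)Nc3ccc(S(N)(=O)=O)cc3C)ccc3cc(Br)ccc23)cc1C` has not yet been measured. It differs from compound 2 by bromo in place of hydrogen on an aromatic carbon, meta to a fused ring and para to a fused ring, in a six-membered aromatic ring of carbon only that is part of a fused system of two rings. Among the compounds with values here, none of the measured steps touches that ring: each of them swaps the aryl on the carbonyl carbon, and each stayed within the scatter. Within the data shown here, no measured step therefore bears directly on the bromine in compound 4, and nothing in the set points to a change beyond the scatter.

The number for compound 4 is accordingly expected to stay close to that of compound 2, with an estimated step of a 1.1-fold lower number from compound 2 to compound 4 (0.04 log units; within the scatter). Compound 4 is estimated at 30000 nM, within a range from 14000 nM to 65000 nM.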

Compound 4, half-maximal cytotoxic concentration: 85200 nM
Compound 4: the middle estimate sits 2.8-fold (0.45 log units) below what was measured; measured number above the stated range.
By their numbers in this assay, from the lowest: compounds 2, 3, 1 and 4 (each within the scatter of the next, the first and the last beyond it).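

In this assay, bromo in place of hydrogen on an aromatic carbon, meta to a fused ring and para to a fused ring, gives a 2.6-fold higher number from compound 2 to compound 4 (0.41 log units; beyond the scatter) and so points to lower toxicity in this test. Within the data shown here, this is the only step that lies beyond the scatter and the only one that touches this ring, whereas the swaps of the aryl on the carbonyl carbon among compounds 1, 2 and 3 could not be told apart. The position therefore responds to this change in a way those swaps did not reveal, although nothing available explains why the number rises.

The compounds shown leave open whether the rise belongs to bromine itself or would also follow from chlorine, a methoxy group or an amine on the same carbon, and whether bromo on another carbon of this ring would do the same. They also leave open whether the step carries over to the aryl groups of compound 1 and compound 3, since bromo on this ring is seen here only with the 3,4-dimethylphenyl of compound 2.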